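The source may report more compounds than this note shows. Statements on the series, on what has been measured and on what is new or still open speak of the compounds shown alone.

Compound 1 `CCn1c(CNc2ccccc2)nnc1SCC(=O)Nc1ccc(Cl)cc1` and compound 2 `CCn1c(CNc2ccccc2)nnc1SCC(=O)Nc1ccc(C(=O)NC)cc1` share one core and differ in a single place on the aromatic ring. In an assay on isolated protein for inhibition of long-chain fatty acid transport protein 1 (Homo sapiens) (a lower number here means a stronger inhibitor, a higher number a weaker inhibitor), compound 1 gives only a limit, > 1000 nM. In this assay compound 2 likewise gives only a limit, > 1000 nM. The step that the two limits leave unreadable from compound 1 to compound 2 cannot be read, and compound 2 stands at the limit with no number of its own, as the limit of > 1000 nM in this assay, at which 2 of the 2 values shown sit, records. Compound 3 `CCn1c(CNc2ccccc2)nnc1SCC(=O)Nc1ccc(C(=O)OC(C)(C)C)cc1` carries tert-butoxy in place of methylamino on a carbonyl carbon. With no readable step to lean on, compound 3 is expected near that same limit, estimated at 3000 nM between 1000 nM and 20000 nM. The expected step that the limit leaves unreadable from compound 2 to compound 3 is accordingly none beyond the scatter.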

Compound 3, half-maximal inhibitory concentration: > 1000 nM
Compound 3: only a limit was reported; the forecaster's own chance of this, stated with the estimate: 75%; the middle value lies beyond the limit too.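

Compound 3 also gives only a limit, and the steps among compound 1, compound 2 and compound 3 cannot be read: the limit of > 1000 nM in this assay, at which 3 of the 3 values shown sit. The compounds shown leave open how strongly any of the three inhibits the protein, and whether chloro, methylcarbamoyl and tert-butoxycarbonyl differ at all.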